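Working notes: step from compound 3 to compound 4

This account rests on a few compounds, and the source may have more. Where it says the series, first, only, none or still open, it means among the compounds named here.

Measured so far:
compound 1 `CC(C)OC(=O)N1CCC(Oc2cccc3c2CCN3c2ccc(S(C)(=O)=O)cc2)CC1` — 70%
compound 2 `CC(C)OC(=O)N1CCC(Oc2ncnc3c2CCN3c2ccc(S(C)(=O)=O)cc2)CC1` — 154%
compound 3 `CC(C)COC(=O)N1CCC(Oc2ncnc3c2CCN3c2ccc(S(C)(=O)=O)cc2F)CC1` — 94%

In a functional assay on CHO-K1 cells with Glucose-dependent insulinotropic receptor (Homo sapiens) as the target, read by a luciferase reporter, with a stated time of 5 h (a higher number here means a larger maximal response, a lower number a smaller maximal response), compound 3 gives 94%, the second highest of the three numbers. Compound 1 is the nearest, lower by a margin beyond the scatter, and compound 2 is the furthest, higher by a margin beyond the scatter. Compound 4 `CS(=O)(=O)c1ccc(N2CCc3c(OC4CCN(C5=NCCCN5)CC4)ncnc32)c(F)c1` has not yet been measured in this assay. It differs from compound 3 as follows: a group of 6 heavy atoms (4 carbon, 2 nitrogen; one six-membered non-aromatic ring with 2 hetero atoms) in place of a group of 7 heavy atoms (5 carbon, 2 oxygen; no ring), on an amine nitrogen in a ring. Among the measured compounds shown here, no pair of measured compounds differs in a single place, so no step of this kind is known, and all three measured compounds carry the same kind of group on that amine nitrogen in a ring. The change swaps a group with no ring for one with a six-membered non-aromatic ring with 2 hetero atoms and a hydrogen-bond donor; the maximal response may therefore move in either direction. A downward step of moderate size is expected, a number 14 percentage points lower from compound 3 to compound 4 (beyond the scatter), but a step within the scatter cannot be excluded. For compound 4 the expected value in this assay is 80%, with a range from 40% to 130%.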

Compound 4, largest response reached (reported as percent of maximum), in percent of the reference or control that the assay uses: 66%
For compound 4 the middle estimate is 14 percentage points above the measured one; low and high end bracket the measured number.
By their numbers in this assay, from the lowest: compounds 4 and 1 (each within the scatter of the next); then compound 3; then compound 2.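

Among the compounds shown here, compound 3 to compound 4 is the first change at this position, since all earlier compounds carry the same kind of group on the amine nitrogen in a ring. In this assay, replacing isobutoxycarbonyl with the six-membered non-aromatic ring with 2 hetero atoms gives a number 28 percentage points lower from compound 3 to compound 4 (beyond the scatter), a modest loss beyond the scatter. The isobutoxycarbonyl group is therefore not required for a response, as compound 4 still gives 66%. No available data explain this step.

This single pair cannot separate the contributions of the ring, the hydrogen-bond donor and the loss of the oxygen atoms. From the compounds shown here alone, it also remains open how an open-chain guanidine or a pyrimidine ring on the same nitrogen would compare, and whether the step holds on another core.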